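The source may report more compounds than this note shows. Statements on the series, on what has been measured and on what is new or still open speak of the compounds shown alone.

Compound 1 `Cc1ccn2nc(C)c(C(=O)NCc3ccc(-c4ccc(OC(F)(F)F)cc4)cc3)c2c1` gives 50700 nM in an ADME assay on Vero cells (Chlorocebus sabaeus) for cytotoxicity, read by CCK-8 assay, with a stated time of 72 h; on this read-out higher numbers stand for weaker inhibition and lower numbers for stronger inhibition.
Compound 2 `Cc1ccc2c(C(=O)NCc3ccc(N4CCC(c5ccc(OC(F)(F)F)cc5)CC4)cc3)c(C)nn2c1` gives > 100000 nM in this assay.

Compound 2 stands only at a limit of this assay, with no number of its own, as the limit of > 100000 nM in this assay, at which 1 of the 2 values shown sits, shows. Compound 3 `CCc1nn2ccc(Cl)cc2c1C(=O)NCc1ccc(N2CCC(c3ccc(OC(F)(F)F)cc3)CC2)cc1` carries, in place of the core of compound 2, (a group of 12 heavy atoms (9 carbon, 2 nitrogen, 1 chlorine; one five-membered aromatic ring with 2 hetero atoms, one six-membered aromatic ring with 1 hetero atom) in place of a group of 11 heavy atoms (9 carbon, 2 nitrogen; one five-membered aromatic ring with 2 hetero atoms, one six-membered aromatic ring with 1 hetero atom), on a carbonyl carbon). Among the compounds with values here, no step between measured compounds is available to gauge this change, so no shift beyond the scatter is expected in this assay. Compound 3 is expected to give 100000 nM, within 50000 nM to 200000 nM, an expected step of a number no higher from compound 2 to compound 3 (the limit leaves the size open) that most likely leaves it at the limit as well.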

Compound 3, half-maximal inhibitory concentration: > 100000 nM
Compound 3: only a limit was reported; the forecaster's own chance of this, stated with the estimate: 65%; the middle value lies on the limit itself.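

No step can be read between compound 2 and compound 3 in this assay, as both stand at a limit: the limit of > 100000 nM in this assay, at which 2 of the 3 values shown sit.

The compounds shown leave open whether the group entering in compound 3 changes the read-out at all.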